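Fluoro for nitro in a thiosemicarbazone-like series

The source may hold more compounds than are shown below. What is called first, only, known or untested is meant among the compounds shown, and "the series" means these compounds.

Measured in a functional assay on T98G cells (Homo sapiens) for cytotoxicity, read by MTT assay, with a stated time of 48 h; on this read-out lower numbers stand for stronger inhibition and higher numbers for weaker inhibition:
- Compound 1 `CC(=NNC(=S)Nc1cccc(F)c1)c1ccccn1`: 12 nM
- Compound 2 `C/C(=N/NC(=S)Nc1cccc([N+](=O)[O-])c1)c1ccccn1`: 140 nM
- Compound 3 `C/C(=N\NC(=S)Nc1cccc([N+](=O)[O-])c1)c1ccccn1`: 140 nM

Compound 2 stands level with compound 3, and together they hold the highest of the three numbers, well above compound 1. Compound 4 `C/C(=N/NC(=S)Nc1cccc(F)c1)c1ccccn1` keeps the double bond as drawn in compound 2 and differs from it by fluoro in place of nitro on an aromatic carbon. Among the measured compounds shown here, one measured step bears on the configuration, given the fact that compounds 2 and 3 differ only in the configuration as drawn: no change at the digits printed from compound 2 to compound 3 (within the scatter). Configuration is thus not expected to matter much in this assay. Compound 1 carries the same fluoro group with no configuration drawn, and it gives 12 nM, so a clear fall is expected, beyond the scatter. The expected step is a 12-fold lower number from compound 2 to compound 4 (1.07 log units; beyond the scatter). For compound 4 the estimate is 12 nM, with an expected range of 6 nM to 25 nM.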

Compound 4, half-maximal inhibitory concentration: 12 nM
Compound 4: the middle estimate sits on the measured number at the digits printed; the measured number falls inside the stated range.
By their numbers in this assay, from the lowest: compounds 1 and 4 (each within the scatter of the next); then compounds 2 and 3 (each within the scatter of the next).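

In this assay, the pair with the double bond drawn alike gives a 12-fold lower number from compound 2 to compound 4 (1.07 log units; beyond the scatter), so the gap between fluoro and nitro at this aromatic carbon no longer depends on a compound without a drawn configuration. With fluoro, the comparison of the drawn and undrawn double bond shows no change at the digits printed from compound 1 to compound 4 (within the scatter), and this reading rests on one fact: the fact that one of compounds 1 and 4 is drawn with a defined configuration and the other without, at the place where they differ

As far as these compounds go, whether an amine, methoxy or chloro at this place would fall nearer compound 4 or compound 2 stays open. From the compounds shown here alone, what sets fluoro and nitro apart here also stays open.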